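The compounds below may be only part of what the source reports. "The series", "measured", "known", "first", "only" and "open" are said of these compounds alone.

Measured so far in a physicochemical assay for solubility, measured as thermodynamic solubility, at pH 7.4; on this read-out higher numbers stand for higher solubility and lower numbers for lower solubility:
- compound 1 `O=C(O)Cn1nc(Cc2nc3cc(Cl)c(OCC(F)F)cc3[nH]2)c2ccccc2c1=O` (> 1000 ug/mL)
- compound 2 `C[C@H](C(=O)O)n1nc(Cn2cc3cc(OCC4CC4)c(Cl)cc3n2)c2ccccc2c1=O` (958 ug/mL)
- compound 3 `C[C@H](C(=O)O)c1nn(Cc2cn3cc(OCC4CC4)c(Cl)cc3n2)c2ccccc2c1=O` (892 ug/mL)

The reading for compound 1 (> 1000 ug/mL) is a limit of the assay and not a number. Its position is therefore bounded on one side only (the limit of > 1000 ug/mL in this assay, at which 1 of the 3 values shown sits). The readings for compound 2 (958 ug/mL) and compound 3 (892 ug/mL) are numbers and lie within the scatter of each other.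

The next compound is compound 4 (`O=C(O)Cn1nc(Cc2nc3cc(Cl)c(OCC4CC4)cc3[nH]2)c2ccccc2c1=O`). It keeps the core of compound 1 and has cyclopropyl in place of difluoromethyl on a saturated chain carbon bound to an oxygen on an aromatic ring, so that 2,2-difluoroethoxy becomes cyclopropylmethoxy (cyclopropyl in place of difluoromethyl on a saturated chain carbon bound to an oxygen on an aromatic ring).

Among the compounds with values here, no measured pair isolates this change, so the expectation rests on indirect evidence. Cyclopropylmethoxy is already present on other cores, in compound 2 (958 ug/mL) and in compound 3 (892 ug/mL). A small downward step in this assay is expected (an at least 1.3-fold lower number from compound 1 to compound 4 (0.12 log units; that floor lies within the scatter)), and its size remains uncertain while the starting point is only a limit. The estimate for compound 4 is 750 ug/mL (estimated range 350 ug/mL to 1500 ug/mL).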

Compound 4, solubility: 395 ug/mL
Compound 4: middle estimate off by 1.9-fold (0.28 log units), on the high side; the measured number falls inside the stated range.
By their numbers in this assay, from the lowest: compound 4; then compounds 3 and 2 (each within the scatter of the next). At a limit, above all of these: compound 1.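

On the shared core, cyclopropyl in place of difluoromethyl on a saturated chain carbon bound to an oxygen on an aromatic ring now has a direct reading in this assay, which gives an at least 2.5-fold lower number from compound 1 to compound 4 (0.40 log units; beyond the scatter). The heavy-atom count of the group stays the same and neither group carries hydrogen-bond donors or acceptors, so this step beyond the scatter comes with no change in those counts. Compound 1 reads > 1000 ug/mL, which is a limit and not a number, so the step gives only a floor and its full size cannot be read: the limit of > 1000 ug/mL in this assay, at which 1 of the 4 values shown sits.

How the same change reads in this assay on the cores of compound 2 and compound 3 stays open, as neither has a 2,2-difluoroethoxy partner among the compounds shown. Also open, on these data alone, is whether the step follows the ring of cyclopropyl or the fluorine of difluoromethyl, which a plain ethyl chain on the same oxygen could separate, and how a terminal amine on a longer chain at this position would read.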